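This account rests on a few compounds, and the source may have more. Where it says the series, first, only, none or still open, it means among the compounds named here.

Compound 3 `CCN1CCc2c(c(C(C)(C)C)nn2C(=O)Nc2cc(C)ccc2C)C1` is one of three compounds whose ability to dampen the pain response of a mouse has been measured in a functional assay on the whole organism (strain Swiss albino) for inhibition, with Mus musculus as the target, in the formalin test, with stated times of 30 min and 5 min, at a dose of 100 mg/kg (on this read-out higher numbers stand for more inhibition at the one dose given (going by the name of the read-out) and lower numbers for less inhibition), where compound 3 gives 0%. Compound 2 `CCN1CCc2c(c(C(C)(C)C)nn2C(=O)Nc2ccc(Br)cc2)C1` gives 0% in this assay, and compound 1 `CCN1CCc2c(c(C)nn2C(=O)Nc2ccc(C)cc2C)C1` gives 7%, so all three sit at the bottom of the scale, within the scatter of one another. Going by the values given here, the only single-point change measured so far is no change at the digits printed from compound 2 to compound 3 (within the scatter), which shows that swapping the ring on the amide-type nitrogen left the read-out unchanged.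

Compound 4 `CCN1CCc2c(c(C(C)(C)C)nn2C(=O)Nc2ccc(C)cc2C)C1` differs from compound 3 as follows: 2,4-dimethylphenyl in place of 2,5-dimethylphenyl on an amide-type nitrogen. This change again alters only the ring on the amide-type nitrogen. Among the compounds with values here, since compound 2 and compound 3 showed no step on such a swap, and since compound 1, which carries the same 2,4-dimethylphenyl group, gives 7%, the step of a number 3 percentage points higher from compound 3 to compound 4 (within the scatter) is expected to stay within the scatter. Compound 4 is therefore expected to give about 3%, between 0% and 15%.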

Compound 4, a percentage reported as inhibition, in the whole organism at one dose (the size of the read-out at that dose, not a potency): 15.7%
Compound 4: the middle estimate sits 12.7 percentage points below what was measured, and the stated range ends below it.
By their numbers in this assay, from the lowest: compounds 2, 3, 1 and 4 (each within the scatter of the next, the first and the last beyond it).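

On the amide-type nitrogen, the arrangement of the ring alone can move the read-out in this assay: 2,4-dimethylphenyl in place of 2,5-dimethylphenyl, a swap that keeps the same atoms, gives a number 15.7 percentage points higher from compound 3 to compound 4 (beyond the scatter). The same group in place of 4-bromophenyl gives a number 15.7 percentage points higher from compound 2 to compound 4 (beyond the scatter), so among the compounds with a tert-butyl group, a swap on this nitrogen is no longer always silent. By contrast, tert-butyl in place of methyl on an aromatic carbon gives a number 8.7 percentage points higher from compound 1 to compound 4 (within the scatter), so that change shows no clear effect here.

Nothing available explains why the 2,4-dimethylphenyl ring stands apart from the other two rings. Going by these compounds, it remains open how the read-out would respond to a methoxy group or an amine on this ring in place of the methyl groups.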